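The source may hold more compounds than are shown below. What is called first, only, known or untested is meant among the compounds shown, and "the series" means these compounds.

Measured so far in a functional assay on HCT-116 cells (Homo sapiens) for antiproliferative activity, read by MTT assay, with a stated time of 48 h (on this read-out lower numbers stand for stronger inhibition and higher numbers for weaker inhibition), and compared below:
- compound 1 `CC(CCO)n1cnc2c(Cl)nc(F)nc21` gives 19800 nM
- compound 2 `CCCC(CCO)n1cnc2c(Cl)nc(F)nc21` gives 16500 nM
- compound 3 `CCCCCCCC(CCO)n1cnc2c(Cl)nc(F)nc21` gives 17600 nM

Compound 3 stands within the scatter of both other compounds (a 1.1-fold higher number from compound 2 to compound 3 (0.03 log units; within the scatter); a 1.1-fold lower number from compound 1 to compound 3 (0.05 log units; within the scatter)). Compound 4 `OCCCn1cnc2c(Cl)nc(F)nc21` differs from compound 3 by hydrogen in place of heptyl on a saturated chain carbon bound to an aromatic nitrogen and a saturated chain carbon as hydrogen in place of heptyl on a saturated chain carbon bound to an aromatic nitrogen and a saturated chain carbon. The chain steps bearing on this change are small, and all lie within the scatter (a 1.2-fold lower number from compound 1 to compound 2 (0.08 log units; within the scatter); a 1.1-fold lower number from compound 1 to compound 3 (0.05 log units; within the scatter); a 1.1-fold higher number from compound 2 to compound 3 (0.03 log units; within the scatter)). None of them removes the whole group, so the range is kept wide. In this assay no step beyond the scatter is expected, and the expected step runs (a 1.0-fold higher number from compound 3 to compound 4 (0.01 log units; within the scatter)). Compound 4 is estimated at 18000 nM within an expected range of 10000 nM to 32000 nM for now.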

Compound 4, half-maximal inhibitory concentration: 39800 nM
Estimate against measurement, compound 4: 2.2-fold (0.34 log units) below; measured number outside the range, above it.
By their numbers in this assay, from the lowest: compounds 2, 3, 1 and 4 (each within the scatter of the next, the first and the last beyond it).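

In this assay, going by these compounds alone, the saturated chain carbon bound to an aromatic nitrogen and a saturated chain carbon now shows steps beyond the scatter: hydrogen in place of heptyl (a 2.3-fold higher number from compound 3 to compound 4 (0.35 log units; beyond the scatter)) and hydrogen in place of propyl (a 2.4-fold higher number from compound 2 to compound 4 (0.38 log units; beyond the scatter)) both give higher numbers, whereas the alkyl groups alone showed no such step. Hydrogen in place of methyl stays within the scatter (a 2.0-fold higher number from compound 1 to compound 4 (0.30 log units; within the scatter)), so compound 1 goes against a clean split between hydrogen and alkyl. No measurement at hand accounts for these steps. Going by these compounds, whether an amine or a carboxylic acid on this carbon would match the alkyl compounds remains open.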